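Swapping the ring substituent on a potent antagonist

This account rests on a few compounds, and the source may have more. Where it says the series, first, only, none or still open, it means among the compounds named here.

Three compounds share one core and differ only in the saturated ring attached to it. In a functional assay on CHO-K1 cells for antagonist activity at transient receptor potential cation channel subfamily V member 1 (Homo sapiens), read by FLIPR (on this read-out higher numbers stand for weaker inhibition and lower numbers for stronger inhibition), compound 1 `CC(C(=O)NCc1ccc(C(F)(F)F)nc1N1CCCC1)c1ccc(NS(C)(=O)=O)c(F)c1` gives 0.6 nM, compound 2 `CC(C(=O)NCc1ccc(C(F)(F)F)nc1N1CCCCC1C)c1ccc(NS(C)(=O)=O)c(F)c1` gives 2.9 nM, and compound 3 `CC(C(=O)NCc1ccc(C(F)(F)F)nc1N1CCC(Cc2cc(F)cc(F)c2)CC1)c1ccc(NS(C)(=O)=O)c(F)c1` gives 0.4 nM. Compound 3 has the lowest number of the three, but the number for compound 1 lies within the scatter of it; only compound 2 stands clearly apart. Going by the values given here, the one single-place step measured, a 4.8-fold higher number from compound 1 to compound 2 (0.68 log units; beyond the scatter), is modest. Compound 4 `CC(=O)OC1CCN(c2nc(C(F)(F)F)ccc2CNC(=O)C(C)c2ccc(NS(C)(=O)=O)c(F)c2)CC1` is not yet measured; it differs from compound 3 by acetoxy in place of 3,5-difluorobenzyl on a saturated ring carbon. Among the compounds with values here, no measured step changes this substituent, so the expectation rests on the narrow spread across compounds 1, 2 and 3. The step of a 3.8-fold higher number from compound 3 to compound 4 (0.57 log units; beyond the scatter) is therefore expected to be small in this assay, most likely a somewhat higher number. For compound 4 the estimated value in this assay is 1.5 nM, with a range from 0.4 nM to 6 nM.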

Compound 4, inhibition constant: 4 nM
For compound 4 the middle estimate is 2.7-fold (0.43 log units) below the measured one, within the range that was stated.
By their numbers in this assay, from the lowest: compounds 3 and 1 (each within the scatter of the next); then compounds 2 and 4 (each within the scatter of the next).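

In this assay, this ring carbon, three ring bonds from the ring nitrogen, now has a measured change: acetoxy in place of 3,5-difluorobenzyl gives a 10-fold higher number from compound 3 to compound 4 (1.00 log units; beyond the scatter) and shows that the group held here matters beyond the scatter. Replacing the whole saturated ring, 4-acetoxypiperidin-1-yl in place of pyrrolidin-1-yl gives a 6.7-fold higher number from compound 1 to compound 4 (0.82 log units; beyond the scatter) and is also a step beyond the scatter. In contrast, 4-acetoxypiperidin-1-yl in place of 2-methylpiperidin-1-yl gives a 1.4-fold higher number from compound 2 to compound 4 (0.14 log units; within the scatter) and leaves those two substituents indistinguishable in this read-out.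

Nothing available explains the step from 3,5-difluorobenzyl to acetoxy. On these data alone, it also remains open where a hydroxyl, an amine or a carboxylic acid on this ring carbon would fall, and whether a plain benzyl group without the two fluorines would stay close to compound 3.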